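The compounds below may be only part of what the source reports. "The series", "measured", "known", "first", "only" and "open" are said of these compounds alone.

Three compounds have been measured in a functional assay (trachea) with Rattus norvegicus as the target; on this read-out lower numbers stand for lower potency and higher numbers for higher potency (the scale is a negative logarithm):

compound 1, `CC(=O)Oc1ccc2c(c1)C(n1ccccc1=O)=CC(C)(C)O2`, gives 4.97
compound 2, `CC1(C)C=C(n2ccccc2=O)c2cc(OCC(=O)c3ccc(F)cc3)ccc2O1`, gives 4.77
compound 3, `CC1(C)C=C(n2ccccc2=O)c2cc(OC(=O)Nc3ccccc3F)ccc2O1`, gives 4.22

Compound 3 stands lowest of the three. Its step from compound 2 is a number 0.55 log units lower from compound 2 to compound 3 (beyond the scatter), and from compound 1 it is a number 0.75 log units lower from compound 1 to compound 3 (beyond the scatter), both beyond the scatter, while the step of a number 0.20 log units lower from compound 1 to compound 2 (within the scatter) lies within it.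

Compound 4, `CC1(C)C=C(n2ccccc2=O)c2cc(OC(=O)Nc3ccc(F)cc3)ccc2O1`, has not been measured. The change from compound 3 is 4-fluorophenyl in place of 2-fluorophenyl on an amide-type nitrogen. Among the measured compounds shown here, none of the measured steps moves a fluorine on a ring: the two steps that involve compound 3 bring in the whole (2-fluorophenyl)carbamoyl group, and the step to compound 2 brings in a ((4-fluorophenyl)carbonyl)methyl group in a different setting. For the measured compounds named here, no measured step therefore bears directly on this change, and the expected step for compound 4 in this assay is a number 0.08 log units higher from compound 3 to compound 4 (within the scatter), none beyond the scatter. Compound 4 is estimated at 4.3, with a range from 3.8 to 4.8.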

Compound 4, logarithm of the reciprocal of the active concentration, log(1/C): 4.37
The estimate for compound 4 lay 0.07 log units below the measured number, within the range that was stated.
By their numbers in this assay, from the lowest: compounds 3 and 4 (each within the scatter of the next); then compounds 2 and 1 (each within the scatter of the next).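

In this assay, 4-fluorophenyl in place of 2-fluorophenyl on the amide-type nitrogen gives a number 0.15 log units higher from compound 3 to compound 4 (within the scatter), so between these two compounds the change of fluorophenyl group does not show up in the read-out. The other steps show that the gap seen with compound 3 remains with the 4-fluorophenyl group: (4-fluorophenyl)carbamoyl in place of ((4-fluorophenyl)carbonyl)methyl gives a number 0.40 log units lower from compound 2 to compound 4 (beyond the scatter), and (4-fluorophenyl)amino in place of methyl on the carbonyl carbon gives a number 0.60 log units lower from compound 1 to compound 4 (beyond the scatter). No available evidence accounts for these results.

The compounds shown leave open whether an unsubstituted phenyl or a cyclohexyl on the amide-type nitrogen would read any differently. They also leave open what a methyl in place of the amide hydrogen would do.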